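The source may hold more compounds than are shown below. What is called first, only, known or untested is meant among the compounds shown, and "the series" means these compounds.

Measured so far in a functional assay on Huh-5-2 cells (Homo sapiens), read by MTT assay; on this read-out higher numbers stand for lower toxicity in this test and lower numbers for higher toxicity in this test:
- compound 1 `O=C(O)c1ccc2c(c1)nc(-c1ccc(OCc3ccccc3-c3ccc(Cl)cc3)cc1)n2C1CCCCC1` gives 25000 nM
- compound 2 `CN(C)C(=O)c1ccc(-c2ccc(Cl)cc2)c(COc2ccc(-c3nc4cc(C(=O)O)ccc4n3C3CCCCC3)cc2)c1` gives 28000 nM

Within the data shown here, compound 2, at 28000 nM, stands level with compound 1, the only other measured compound, and the two values lie within the scatter of each other. Compound 3 `CN(C)C(=O)c1ccc(-c2ccc(Cl)cc2)c(COc2ccc(-c3nc4cc(C(=O)O)ccc4n3C3CCCCC3)c(F)c2)c1` differs from compound 2 by fluoro in place of hydrogen on an aromatic carbon. Among the measured compounds shown here, one measured step bears on this, and only indirectly: a 1.1-fold higher number from compound 1 to compound 2 (0.05 log units; within the scatter). For the measured compounds named here, that step involved dimethylcarbamoyl in place of hydrogen, also on an aromatic carbon, and no measured step covers fluoro itself. With so little data, no shift beyond the scatter is expected in this assay, in either direction. The estimated step is a 1.0-fold lower number from compound 2 to compound 3 (0.02 log units; within the scatter). The value expected for compound 3 is 27000 nM, with an estimated range from 13000 nM to 50000 nM.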

Compound 3, half-maximal cytotoxic concentration: 26000 nM
For compound 3 the middle estimate is 1.0-fold (0.02 log units) above the measured one, within the range that was stated.
By their numbers in this assay, from the lowest: compounds 1, 3 and 2 (each within the scatter of the next).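

In this assay, fluoro in place of hydrogen on an aromatic carbon, ortho to a large group and meta to a large group, gives a 1.1-fold lower number from compound 2 to compound 3 (0.03 log units; within the scatter), so this place in the series tolerates a single fluorine atom with no shift beyond the scatter. Among these compounds, compounds 1 and 2 both carry hydrogen here, and their step, a 1.1-fold higher number from compound 1 to compound 2 (0.05 log units; within the scatter), concerned dimethylcarbamoyl at another place, so this is the only direct reading for this carbon. No measurement shown explains why the read-out stays level.

As far as these compounds go, whether a methoxy group or an amine on the same carbon would also stay within the scatter remains open. So does whether fluoro would behave the same way in a compound lacking the dimethylcarbamoyl group, such as compound 1.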